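Ester variation on a shared core: buffer stability notes

The source may report more compounds than this note shows. Statements on the series, on what has been measured and on what is new or still open speak of the compounds shown alone.

Measured so far:
- compound 1 `C[C@@H](O)[C@H]1C(=O)N2C(C(=O)OCC(F)(F)F)=C(S[C@@H]3CN[C@H](C(=O)Nc4cccc(C(=O)O)c4)C3)[C@H](C)[C@H]12` gives > 95% in a physicochemical assay for metabolic stability, read by LC-MS, in phosphate buffer, with a stated time of 3 h, at pH 7.4, tested at 50 uM (on this read-out higher numbers stand for a more stable compound and lower numbers for a less stable compound), which is a limit of the assay and not a number.
- compound 2 `C[C@@H](O)[C@H]1C(=O)N2C(C(=O)OCOC(=O)C3CCCCC3)=C(S[C@@H]3CN[C@H](C(=O)Nc4cccc(C(=O)OCOC(=O)C5CCCCC5)c4)C3)[C@H](C)[C@H]12` gives > 95% in this assay, again only a limit.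

Compound 1 therefore stands at the upper limit of this assay, with no number beneath it; the same holds for the only other entry, as summarised by the limit of > 95% in this assay, at which 2 of the 2 values shown sit. Going by the values given here, no step between measured compounds exists, so no measured direction is available.

Compound 3 `CC(C)C(=O)OCOC(=O)C1=C(S[C@@H]2CN[C@H](C(=O)Nc3cccc(C(=O)O)c3)C2)[C@H](C)[C@@H]2[C@@H]([C@@H](C)O)C(=O)N12` differs from compound 1 by (isopropylcarbonyl)oxy in place of trifluoromethyl on a saturated chain carbon bound to an oxygen next to a carbonyl group. With only limits in hand, no change beyond the scatter is expected. Compound 3 is estimated at 93%, within 80% to 99%. The implied step a number at least 2 percentage points lower from compound 1 to compound 3 (that floor lies within the scatter) is expected to stay within the scatter.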

Compound 3, percent of the compound remaining: > 95%
Compound 3 was reported as a limit; the forecaster's own chance of this, stated with the estimate: 60%; middle value at least 2 percentage points from the limit.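

No step from compound 1 to compound 3 can be read in this assay, because all the values are limits: the limit of > 95% in this assay, at which 3 of the 3 values shown sit.

From the compounds shown here alone, whether compound 1, compound 2 and compound 3 differ at all in this assay remains open.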